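The source may hold more compounds than are shown below. What is called first, only, known or untested is meant among the compounds shown, and "the series" means these compounds.

Compounds measured so far:
- compound 1, `Cn1c(=O)c(=O)n(C2CCCC2)c2nc(N/N=C/c3ccc(F)c(Cl)c3)ncc21`: 9410 nM
- compound 2, `Cc1cc(C)c(/C=N/Nc2ncc3c(n2)n(C2CCCC2)c(=O)c(=O)n3C)c(C)c1`: 12000 nM
- compound 3, `COc1ccc(/C=N/Nc2ncc3c(n2)n(C2CCCC2)c(=O)c(=O)n3C)cc1`: the value > 100000 nM is a limit of the assay, not a number

All three were tested in a functional assay on A549 cells (Homo sapiens) for antiproliferative activity, read by MTT assay; a higher number here means a weaker inhibitor, a lower number a stronger inhibitor. Among the numbers shown, compound 1 gives the lowest, with compound 2 nearest: the step of a 1.3-fold higher number from compound 1 to compound 2 (0.11 log units; within the scatter) stays within the usual scatter. Compound 3 sits at the limit (the limit of > 100000 nM in this assay, at which 1 of the 3 values shown sits). The steps of an at least 10-fold higher number from compound 1 to compound 3 (1.02 log units; beyond the scatter) and an at least 8.3-fold higher number from compound 2 to compound 3 (0.92 log units; beyond the scatter) are therefore both clear losses.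

The compound now in question is compound 4, `Cn1c(=O)c(=O)n(C2CCCC2)c2nc(N/N=C/c3cc([N+](=O)[O-])ccc3Cl)ncc21`. It differs from compound 1 only at the group on the carbon with a double bond to nitrogen: 2-chloro-5-nitrophenyl in place of 3-chloro-4-fluorophenyl on a carbon with a double bond to nitrogen.

Every measured step changes exactly this group, so all three bear on the question. One swap of this group cost nothing beyond the scatter, while two others cost a great deal. A swap into compound 4 could thus land anywhere from unchanged to well weaker. Taking a middle road, compound 4 is expected to be somewhat weaker than compound 1, the step of a 1.6-fold higher number from compound 1 to compound 4 (0.20 log units; within the scatter) being the estimate. For compound 4 the expected value is 15000 nM, with a likely range from 4000 nM to 60000 nM.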

Compound 4, half-maximal inhibitory concentration: 8780 nM
Compound 4: the middle estimate sits 1.7-fold (0.23 log units) above what was measured, within the range that was stated.
By their numbers in this assay, from the lowest: compounds 4, 1 and 2 (each within the scatter of the next). At a limit, above all of these: compound 3.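

In this assay, among these compounds, the step of a 1.1-fold lower number from compound 1 to compound 4 (0.03 log units; within the scatter) shows that this place on the carbon with a double bond to nitrogen accepts 2-chloro-5-nitrophenyl, a ring with a nitro group that none of the earlier compounds carried, with no change beyond the scatter, and the step of a 1.4-fold lower number from compound 2 to compound 4 (0.14 log units; within the scatter) also stays within it. Three differently substituted phenyl rings now give numbers within the scatter of one another, and compound 3 alone goes against that picture, as the step of an at least 11-fold lower number from compound 3 to compound 4 (1.05 log units; beyond the scatter) makes plain. Compound 3 stands at a limit of the assay, not at a number: the limit of > 100000 nM in this assay, at which 1 of the 4 values shown sits.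

What sets 4-methoxyphenyl apart from the other three groups stays open, since these numbers show that it differs but not why. On these data alone, whether a phenyl ring bearing an amine or a carboxylic acid, or a plain alkyl chain in place of the ring, would fall with compounds 1, 2 and 4 or with compound 3 also remains unknown.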